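Swapping the aryl group on the imidazole nitrogen

The source may hold more compounds than are shown below. What is called first, only, known or untested is meant among the compounds shown, and "the series" means these compounds.

Going by the values given here, compound 2 `CC(=O)Nc1ccc(-c2nc3c(c(=O)n(C)c(=O)n3C)n2-c2cccc(F)c2)cc1` is the only compound with a finite value in a functional assay on SK-BR-3 cells (Homo sapiens) for antiproliferative activity, read by MTT assay, with a stated time of 48 h (a lower number here means a stronger inhibitor, a higher number a weaker inhibitor), giving 15400 nM. Compound 1 `COC(=O)Nc1ccc(-c2nc3c(c(=O)n(C)c(=O)n3C)n2-c2ccc(OC)cc2)cc1`, in this assay, reaches only a limit at > 25000 nM; that limit is noted as the limit of > 25000 nM in this assay, at which 1 of the 2 values shown sits. Compound 3 `COc1ccc(-n2c(-c3ccc(NC(C)=O)cc3)nc3c2c(=O)n(C)c(=O)n3C)cc1` differs from compound 2 by 4-methoxyphenyl in place of 3-fluorophenyl on an aromatic nitrogen. No measured step of this kind exists among the shown compounds, so compound 3 is expected to lie near or beyond the limit, a step of a 1.4-fold higher number from compound 2 to compound 3 (0.15 log units; within the scatter) toward weaker inhibition. The estimate for compound 3 is therefore 22000 nM, within the range 8000 nM to 60000 nM.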

Compound 3, half-maximal inhibitory concentration: > 25000 nM
Compound 3 ended at the assay's limit (the forecaster's own chance of this, stated with the estimate: 50%); at least 1.1-fold (0.05 log units) between middle value and limit.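

Going by these compounds, putting 4-methoxyphenyl in place of 3-fluorophenyl on this aromatic nitrogen gives an at least 1.6-fold higher number from compound 2 to compound 3 (0.21 log units; that floor lies within the scatter), so the swap brings no stronger inhibition, though its true size stays unknown. The value of compound 3 is a limit, not a number. The step between compound 1 and compound 3, methyl in place of methoxy on a carbonyl carbon, cannot be read: the limit of > 25000 nM in this assay, at which 2 of the 3 values shown sit.

The compounds shown leave open whether an aryl group carrying an amine or a carboxylic acid on this nitrogen would bring the number clear of the limit.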